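From a Propyl Pyrazole to an Ethyl Pyrazole

The compounds below may be only part of what the source reports. "The series", "measured", "known", "first", "only" and "open" are said of these compounds alone.

- Compound 1 `CCNC(=O)c1noc(-c2cc(C(C)C)c(O)cc2O)c1-c1cc(C(=O)O)no1` gives "not determined" (no result reported)
- Compound 2 `CCCn1ccc(-c2c(C(=O)NCC)noc2-c2cc(C(C)C)c(O)cc2O)n1` gives 49 nM

Among the compounds with values here, the only number so far comes from a functional assay on HCT-116 cells (Homo sapiens) for inhibition (on this read-out higher numbers stand for weaker inhibition and lower numbers for stronger inhibition), where compound 2 gives 49 nM as the sole measured result. Compound 1 has no reported result, so compound 2 cannot yet be ranked against anything and serves simply as the reference point.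

Compound 3 `CCNC(=O)c1noc(-c2cc(C(C)C)c(O)cc2O)c1-c1cnn(CC)c1` keeps the core of compound 2 but carries 1-ethyl-1H-pyrazol-4-yl in place of 1-propyl-1H-pyrazol-3-yl on an aromatic carbon. Both groups are pyrazoles, but the chain on the ring and the point of attachment both differ.

Within the data shown here, no measured pair shows what such a swap does, so the expectation rests on compound 2 alone, at 49 nM in this assay and is necessarily loose. The estimated step is a 1.2-fold lower number from compound 2 to compound 3 (0.09 log units; within the scatter) and no move beyond the usual scatter is expected in either direction. Compound 3 is therefore estimated at 40 nM (expected range 12 nM to 140 nM).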

Compound 3, half-maximal inhibitory concentration: 26 nM
For compound 3 the middle estimate is 1.5-fold (0.19 log units) above the measured one; measured number inside the range.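

In this assay, putting 1-ethyl-1H-pyrazol-4-yl in place of 1-propyl-1H-pyrazol-3-yl gives a 1.9-fold lower number from compound 2 to compound 3 (0.28 log units; within the scatter), so this first measured pair cannot be told apart on this read-out. The position, on an aromatic carbon of the five-membered aromatic ring with 1 nitrogen and 1 oxygen, therefore keeps its activity through a swap that alters both the chain on the pyrazole and the point where the pyrazole attaches, at least for these two groups. No separate measurement is available to explain why the two compounds read alike.

Since the chain and the attachment point changed together, this pair cannot show what either change does alone, and the two could have effects that cancel; 1-propyl-1H-pyrazol-4-yl, which pairs the propyl chain with the new attachment point, would separate them. On these data alone, how far the position's tolerance extends also stays open, for example to a longer chain such as butyl on the pyrazole, or to a pyrazole carrying an amine in place of the chain.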